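A methoxy group added where the record shows only limits

The source may hold more compounds than are shown below. What is called first, only, known or untested is meant among the compounds shown, and "the series" means these compounds.

Compound 2 `CCOC(=O)C1=Cc2ccccc2OC1(OCc1cn(-c2ccccc2)nn1)C(F)(F)F` is the starting point. In a functional assay on MCF7 cells (Homo sapiens) for inhibition, read by MTT assay, with a stated time of 24 h (a higher number here means a weaker inhibitor, a lower number a stronger inhibitor), compound 2 reaches only the limit of > 150000 nM, so no number exists for it. Compound 1 `CCOC(=O)C1=Cc2ccccc2OC1(OCc1cc(-c2ccc(OC)cc2)no1)C(F)(F)F` likewise shows in this assay only the limit of > 150000 nM. Compound 3 `O=C(O)C1=Cc2ccccc2OC1(OCc1cc(-c2cccc(C(F)(F)F)c2)no1)C(F)(F)F` also stops at the limit of > 150000 nM in this assay. Among the compounds with values here, every measured member therefore sits at the same assay limit (the limit of > 150000 nM in this assay, at which 3 of the 3 values shown sit), and no step between measured compounds can be sized or given a direction.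

Compound 4 `CCOC(=O)C1=Cc2ccccc2OC1(OCc1cn(-c2cccc(OC)c2)nn1)C(F)(F)F` differs from compound 2 in one place (methoxy in place of hydrogen on an aromatic carbon). Within the data shown here, no measured pair tells how this change plays out, and the three limits give no hint of direction, so any step in this assay is expected to be none beyond the scatter. Compound 4 is thus expected to give 200000 nM, in a range from 60000 nM to 700000 nM, and most likely to return only another limit. For compound 4 the expected step is a step that the limit leaves unreadable from compound 2 to compound 4.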

Compound 4, half-maximal inhibitory concentration: > 150000 nM
Compound 4: no number, only a limit; the forecaster's own chance of this, stated with the estimate: 85%; the middle value is on the limit's open side.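

Compound 4 gives only a limit, > 150000 nM, so with compound 2 also at a limit in this assay, no step can be read between compound 2 and compound 4. The compounds shown leave open what change to these structures would give a measurable value: the limit of > 150000 nM in this assay, at which 4 of the 4 values shown sit.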